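Swapping Chloro for Fluoro on the Benzylamine Arm

This account rests on a few compounds, and the source may have more. Where it says the series, first, only, none or still open, it means among the compounds named here.

Measured compounds:
Compound 1 `Cc1cc(CNCc2ccc(Cl)cc2)c(C)n1-c1ccc(Cl)cc1`: 0.1 ug/mL
Compound 2 `Cc1cc(CN2CCN(C3C[C@@H]4CC[C@H]3C4)CC2)c(C)n1-c1ccc(Cl)cc1`: 5.6 ug/mL
Compound 3 `Cc1c(CN2CCN(C3CC4CCC3C4)CC2)cc(-c2ccc(Cl)cc2)n1-c1ccc(Cl)cc1`: "not determined" (no result reported)

Three compounds sharing one core were examined in an ADME assay on RAW264.7 cells (Mus musculus) for cytotoxicity, read by trypan blue exclusion, with a stated time of 48 h; on this read-out lower numbers stand for stronger inhibition of growth and higher numbers for weaker inhibition of growth. In this assay, among the measured compounds shown here, compound 1 gives 0.1 ug/mL, the lowest number among the two that were reported, and the only other number, for compound 2, is 5.6 ug/mL. The gap between these two is large and lies well beyond the usual scatter, so compound 1 is clearly the stronger inhibitor of growth of the pair. For compound 3 the entry in this assay reads "not determined" (no result reported).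

The next compound, compound 4 `Cc1cc(CNCc2ccc(F)cc2)c(C)n1-c1ccc(Cl)cc1`, is not yet measured. It differs from compound 1 in one place: fluoro in place of chloro on an aromatic carbon. Nothing else about the molecule changes.

No pair of measured compounds differs only in this way, so there is no shown step to lean on. Such a change is expected to give a small step in this assay for compound 4, a 2.0-fold higher number from compound 1 to compound 4 (0.30 log units; within the scatter), probably toward a slightly higher number, though a step within the scatter would not be surprising either. Compound 4 is therefore estimated at 0.2 ug/mL, within the range 0.05 ug/mL to 0.8 ug/mL.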

Compound 4, concentration for 50% growth inhibition: 26 ug/mL
Compound 4: middle estimate off by 130-fold (2.11 log units), on the low side; measured number outside the range, above it.
By their numbers in this assay, from the lowest: compound 1; then compound 2; then compound 4.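

In this assay, the step of a 260-fold higher number from compound 1 to compound 4 (2.41 log units; beyond the scatter) shows that this place on the benzylamine arm is far from silent for this read-out. Exchanging one halogen for another, with no ring, hydrogen-bond donor, hydrogen-bond acceptor or net charge entering or leaving, is enough to move the number well beyond the scatter, toward much weaker inhibition of growth. Among the compounds shown here, the earlier compounds held no pair differing in one place only, and this pair is the first direct look at what the chloro of the 4-chlorobenzyl group is worth on the shared core, although nothing available explains why the two halogens part so widely here.

The compounds shown do not tell whether chloro is unusual at this place or fluoro is, and bromo, methyl, methoxy or plain hydrogen on the same aromatic carbon would be needed to settle that. They also leave open how the number would respond to the same exchange of chloro for fluoro on the other chlorinated ring, which stays unchanged in compound 1 and compound 4.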